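Swapping 4-chlorophenyl for 2-methylphenyl: what to expect

The source may hold more compounds than are shown below. What is called first, only, known or untested is meant among the compounds shown, and "the series" means these compounds.

Measured in a functional assay on K562 cells (Homo sapiens) for inhibition, read by trypan blue exclusion, with a stated time of 48 h; on this read-out lower numbers stand for stronger inhibition and higher numbers for weaker inhibition:
- Compound 1 `NC(=O)c1cc(Br)ccc1NC(=O)/C=C/c1ccccc1`: 5000 nM
- Compound 2 `NC(=O)c1cc(Cl)ccc1NC(=O)/C=C/c1ccccc1Br`: 10000 nM
- Compound 3 `NC(=O)c1cc(Br)ccc1NC(=O)/C=C/c1ccc(Cl)cc1`: > 10000 nM, a limit of the assay and not a number

Compound 3 stands at the limit of > 10000 nM in this assay, at which 1 of the 3 values shown sits. Its true value is therefore unknown, and any comparison with it is loose.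

The next compound is compound 4 `Cc1ccccc1/C=C/C(=O)Nc1ccc(Br)cc1C(N)=O`, which has not yet been measured in this assay. The structural change is 2-methylphenyl in place of 4-chlorophenyl on a double-bonded chain carbon bound to a double-bonded chain carbon.

Going by the values given here, the one measured step that bears on this is an at least 2.0-fold higher number from compound 1 to compound 3 (0.30 log units; that floor lies within the scatter). That step added the chloro group, and compound 4 no longer has it, carrying a methyl group instead. Compound 1 gives 5000 nM and compound 2 gives 10000 nM, and these two values lie within the usual scatter of each other. They suggest that the numbers in this small set stay close together.

A small move towards lower numbers is therefore expected, and it may not exceed the scatter. The expected change is an at least 1.2-fold lower number from compound 3 to compound 4 (0.09 log units; that floor lies within the scatter). For compound 4 the estimate is 8000 nM, with an expected range of 3000 nM to 20000 nM.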

Compound 4, half-maximal inhibitory concentration: > 10000 nM
Compound 4: only a limit was reported (the forecaster's own chance of this, stated with the estimate: 35%); at least 1.2-fold (0.09 log units) between middle value and limit.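

In this assay compound 4 gives > 10000 nM, which is a limit of the assay and not a number. Placing a methyl group on the aromatic ring in place of hydrogen gives an at least 2.0-fold higher number from compound 1 to compound 4 (0.30 log units; that floor lies within the scatter), so this change, like the earlier chloro change, gives no sign of a lower number, although the floor of the step does not clear the usual scatter. The step from the 4-chlorophenyl group to the 2-methylphenyl group cannot be read, and neither group can be placed ahead of the other on this read-out, since both compounds rest on the same limit: the limit of > 10000 nM in this assay, at which 2 of the 4 values shown sit.

As far as these compounds go, how far compound 3 and compound 4 truly lie beyond that limit remains open, and so does the size of any difference between them. Also open, from the compounds shown here alone, is whether an amine or a carboxylic acid in place of the methyl group on this ring would give a lower number than compound 1, which gives 5000 nM.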